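Hydroxy Addition on a Chloropropyl Amide Analogue

The source may hold more compounds than are shown below. What is called first, only, known or untested is meant among the compounds shown, and "the series" means these compounds.

Compound 1 `CCCCCc1cccc(NC(=O)NC(=O)CCl)c1` and compound 2 `CCCCC(O)c1cccc(NC(=O)NC(=O)CCl)c1` share a core that compound 3 `CCCCCc1cccc(NC(=O)CCCCl)c1` and compound 4 `CCCCC(O)c1cccc(NC(=O)CCCCl)c1` do not: the cores differ by 3-chloropropyl in place of ((chloromethyl)carbonyl)amino on a carbonyl carbon. In a functional assay on MCF7 cells (Homo sapiens) for antiproliferative activity, with a stated time of 48 h (on this read-out lower numbers stand for stronger inhibition and higher numbers for weaker inhibition), compound 1 gives 8300 nM, and compound 2 gives 5700 nM; the step is a 1.5-fold lower number from compound 1 to compound 2 (0.16 log units; within the scatter). For compound 3 this assay reports only a limit, > 100000 nM, so an at least 12-fold higher number from compound 1 to compound 3 (1.08 log units; beyond the scatter) is bounded by the limit (the limit of > 100000 nM in this assay, at which 1 of the 3 values shown sits). The change hydroxy in place of hydrogen on a saturated chain carbon bound to an aromatic carbon and a saturated chain carbon is the same change that takes compound 3 to compound 4, (hydroxy in place of hydrogen on a saturated chain carbon bound to an aromatic carbon and a saturated chain carbon). Compound 4 has not yet been measured in this assay. Since the earlier step of a 1.5-fold lower number from compound 1 to compound 2 (0.16 log units; within the scatter) lay within the scatter, the step that the limit leaves unreadable from compound 3 to compound 4 is expected to be of similar size. Compound 4 is therefore estimated at 150000 nM, most likely reported again as a limit.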

Compound 4, half-maximal inhibitory concentration: > 100000 nM
Compound 4: no number, only a limit (the forecaster's own chance of this, stated with the estimate: 80%); the middle value is on the limit's open side.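

In this assay compound 4 gives > 100000 nM, which is a limit and not a number; compound 3 also carries only a limit, so the hydroxy step between them cannot be read. The change of core can still be followed on the hydroxy pair, where it gives an at least 17-fold higher number from compound 2 to compound 4 (1.24 log units; beyond the scatter), a large step beyond the scatter. The higher number thus comes with the 3-chloropropyl core whether the chain is pentyl or 1-hydroxypentyl, but this does not show that the step has the same size on both: the same change on two cores in this assay, an at least 12-fold higher number (1.08 log units; beyond the scatter) from compound 1 to compound 3 and an at least 17-fold higher number (1.24 log units; beyond the scatter) from compound 2 to compound 4; the limit leaves it open whether they differ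

Going by these compounds, it remains open where compound 3 and compound 4 truly lie past the limit, and whether hydroxy changes anything on that core. On these data alone, how an amine, a carboxylic acid or a longer chain in place of pentyl would read on either core also stays open.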